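Aryl in place of benzyloxy at the ring carbon of compound 2

The compounds below may be only part of what the source reports. "The series", "measured", "known", "first", "only" and "open" are said of these compounds alone.

Of the compounds shown here, three have been measured in an assay on CHO cells for antagonist activity at transient receptor potential cation channel subfamily V member 1 (Homo sapiens), read by FLIPR; on this read-out higher numbers stand for weaker inhibition and lower numbers for stronger inhibition. Compound 1 `Cc1cccc(N2CCN(c3cc(C(F)(F)F)ccc3CNC(=O)C(C)c3ccc(NS(C)(=O)=O)c(F)c3)CC2)c1` gives 1.8 nM in this assay. Compound 2 `CC(C(=O)NCc1ccc(C(F)(F)F)cc1OCc1ccc(F)cc1)c1ccc(NS(C)(=O)=O)c(F)c1` gives 0.5 nM, the lowest number of the three; compound 1 stands at a higher number, beyond the scatter, and compound 3 `C[C@@H](C(=O)NCc1ccc(C(F)(F)F)cc1SC1CCCCC1)c1ccc(NS(C)(=O)=O)c(F)c1`, which gives 13.9 nM, stands furthest off. Among the compounds with values here, no two measured compounds differ in only one place, so no single-change step is available.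

Compound 4 `CC(C(=O)NCc1ccc(C(F)(F)F)cc1-c1ccc(F)c(Cl)c1)c1ccc(NS(C)(=O)=O)c(F)c1` has not yet been measured. Against compound 2 the change is 3-chloro-4-fluorophenyl in place of (4-fluorobenzyl)oxy on an aromatic carbon. The (4-fluorobenzyl)oxy group leaves and 3-chloro-4-fluorophenyl enters on the same aromatic carbon. Within the data shown here, no measured pair shows the effect of this change, so the size of the step rests on the spread of the series alone. The step expected for compound 4 is a 4.0-fold higher number from compound 2 to compound 4 (0.60 log units; beyond the scatter), a move to a higher number that is expected to lie beyond the scatter yet well inside the range the three measured compounds cover. For compound 4 the estimate is 2 nM, with a range from 0.5 nM to 8 nM.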

Compound 4, inhibition constant: 0.6 nM
Estimate against measurement, compound 4: 3.3-fold (0.52 log units) above; low and high end bracket the measured number.
By their numbers in this assay, from the lowest: compounds 2 and 4 (each within the scatter of the next); then compound 1; then compound 3.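

At the aromatic carbon ortho to a large group and meta to a trifluoromethyl group, 3-chloro-4-fluorophenyl in place of (4-fluorobenzyl)oxy reads in this assay as a 1.2-fold higher number from compound 2 to compound 4 (0.08 log units; within the scatter), so this pair is not separated. At this position, a phenyl ring carried directly on the aromatic carbon therefore matches the benzyl ether, and the hydrogen-bond acceptor counted in the leaving group is absent from the entering group without any step beyond the scatter. No measured property bears on this result.

On these data alone, whether the chlorine and fluorine on the entering ring matter remains open, since a plain phenyl or a pyridyl ring at this carbon would be needed to tell. A carboxylic acid or a primary amine on the entering ring would test how far this position accepts other groups.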